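Switching a sulfone for a sulfonamide on a shared core

The source may hold more compounds than are shown below. What is called first, only, known or untested is meant among the compounds shown, and "the series" means these compounds.

Measured so far in a functional assay on K562 cells (Homo sapiens) for inhibition, read by trypan blue exclusion, with a stated time of 72 h; a higher number here means a weaker inhibitor, a lower number a stronger inhibitor:
- compound 1 `Cn1c(=O)c(S(=O)(=O)Cc2ccc(F)cc2)cc2cnc(Nc3ccc4[nH]ccc4c3)nc21` gives 30000 nM
- compound 2 `Cn1c(=O)c(S(=O)(=O)c2ccc(Cl)cc2)cc2cnc(Nc3cnc4ccccc4c3)nc21` gives 15000 nM
- compound 3 `Cn1ccc2cc(Nc3ncc4cc(S(=O)(=O)c5ccc(F)cc5F)c(=O)n(C)c4n3)ccc21` gives 750 nM

Compound 1 stands at the highest of the three numbers, so it is the weakest inhibitor here. Its nearest neighbour on the scale is compound 2, whose number is lower by an amount that stays within the usual scatter, so the two cannot be told apart. Compound 3 sits far lower, well beyond the scatter, and is the clearly stronger inhibitor of the set.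

Compound 4 `Cn1c(=O)c(S(=O)(=O)Nc2ccc(F)cc2F)cc2cnc(Nc3ccc4[nH]ccc4c3)nc21` is the next compound, not yet measured. It differs from compound 1 in one place: (2,4-difluorophenyl)amino in place of 4-fluorobenzyl on a sulfonyl sulfur. The sulfonyl sulfur now carries a nitrogen-linked aromatic group rather than a carbon-linked one, and the group brings one hydrogen-bond donor where before there was none.

Among the compounds with values here, no step between two measured compounds isolates this change, so only a loose expectation is possible. Compound 3 carries a closely related (2,4-difluorophenyl)-bearing sulfonyl group, but its other end also differs, so its low number cannot be credited to that group alone. A modest step toward a lower number is expected, a 3.0-fold lower number from compound 1 to compound 4 (0.48 log units; beyond the scatter), but with wide uncertainty. Compound 4 is estimated at 10000 nM in this assay, with a range from 2000 nM to 50000 nM.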

Compound 4, half-maximal inhibitory concentration: 5000 nM
The estimate for compound 4 lay 2.0-fold (0.30 log units) above the measured number; measured number inside the range.
By their numbers in this assay, from the lowest: compound 3; then compound 4; then compounds 2 and 1 (each within the scatter of the next).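

On a sulfonyl sulfur of the shared core, putting (2,4-difluorophenyl)amino in place of 4-fluorobenzyl gives in this assay a 6.0-fold lower number from compound 1 to compound 4 (0.78 log units; beyond the scatter). This is the first change among these compounds that can be read on its own, and it shows that the number responds to the group on this sulfur while the rest of the molecule stays the same. The entering group differs in its link to the aromatic ring, its fluorines and its hydrogen-bond donor all at once, so the step belongs to the whole group, and nothing shown explains why the number falls.

The compounds shown leave open which of those differences carries the step: a plain phenylamino group on the same sulfur, or a 2,4-difluorobenzyl group, would begin to separate the nitrogen link from the added fluorine. On these data alone, it also remains open whether this swap moves the number by a similar amount when a different aromatic amine sits on the shared core.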